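Aromatic substituent series: from hydroxy to chloro

The source may report more compounds than this note shows. Statements on the series, on what has been measured and on what is new or still open speak of the compounds shown alone.

Measured so far in an assay on cells (Ventricular myocyte) for inhibition of potassium voltage-gated channel subfamily KQT member 1 (Cavia porcellus), read by patch clamp; on this read-out lower numbers stand for stronger inhibition and higher numbers for weaker inhibition:
compound 1 `CCOc1ccc2c(c1)/C(=N/N1CC(=O)N(CCCCN3CCCCC3)C1=O)CCO2` gives 1040 nM
compound 2 `CCCOc1ccc2c(c1)/C(=N/N1CC(=O)N(CCCCN3CCCCC3)C1=O)CCO2` gives 3.2 nM
compound 3 `O=C1CN(/N=C2\CCOc3ccc(O)cc32)C(=O)N1CCCCN1CCCCC1` gives 5400 nM

Compound 3 stands with the highest number of the three; compound 1 is nearest, compound 2 furthest. Both steps reaching compound 3 strip an alkyl from the aromatic oxygen: a 5.2-fold higher number from compound 1 to compound 3 (0.72 log units; beyond the scatter), and a 1700-fold higher number from compound 2 to compound 3 (3.23 log units; beyond the scatter). Compound 4 `O=C1CN(/N=C2\CCOc3ccc(Cl)cc32)C(=O)N1CCCCN1CCCCC1` now differs from compound 3 by chloro in place of hydroxy on an aromatic carbon. Within the data shown here, no measured step exchanges the hydroxy for a group lacking donor and acceptor, so the two steps onto compound 3 bear only indirectly: they show that compound 3 is the weak point of this set. On that basis a lower number is expected for compound 4, with wide uncertainty, the expected step being a 9.0-fold lower number from compound 3 to compound 4 (0.95 log units; beyond the scatter). Compound 4 is estimated at 600 nM, range 60 nM to 6000 nM.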

Compound 4, half-maximal inhibitory concentration: 61000 nM
Compound 4: middle estimate off by 100-fold (2.01 log units), on the low side; the whole stated range lies below it.
By their numbers in this assay, from the lowest: compound 2; then compound 1; then compound 3; then compound 4.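

Chloro in place of hydroxy gives no gain at this position: an 11-fold higher number from compound 3 to compound 4 (1.05 log units; beyond the scatter) and leaves the hydroxy no longer the poorest group in the set. The gap to the alkoxy compounds is wider still, with a 59-fold higher number from compound 1 to compound 4 (1.77 log units; beyond the scatter) and a 19000-fold higher number from compound 2 to compound 4 (4.28 log units; beyond the scatter) and no exception among these four compounds to the alkoxy groups giving the lower numbers. Nothing available explains this order of groups.

Open, from the compounds shown here alone, is whether a butoxy chain extends the fall in number seen from ethoxy to propoxy, and where methoxy falls. An amine or a carboxylic acid at this position also remains to be placed.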